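The source may report more compounds than this note shows. Statements on the series, on what has been measured and on what is new or still open speak of the compounds shown alone.

Of the compounds shown here, three with a shared core have been tested in an ADME assay on MDCK cells (Canis lupus familiaris) for cytotoxicity, read by microscopy, with a stated time of 48 h; on this read-out lower numbers stand for higher toxicity in this test and higher numbers for lower toxicity in this test. Compound 1 `CCCc1csc(CN[C@@H]2C[C@H]3C[C@@H]([C@H]2C)C3(C)C)c1` gives 12500 nM in this assay. Compound 2 `C[C@H]1[C@H](NCc2ccoc2)C[C@H]2C[C@@H]1C2(C)C` reaches only the limit of this assay, > 100000 nM, and so supplies no number. Compound 3 `C[C@H]1[C@H](NCc2cc(C3CC3)cs2)C[C@H]2C[C@@H]1C2(C)C` gives 25000 nM. Among the two numbers shown, compound 3 has the highest, and its nearest neighbour is compound 1, with a step of a 2.0-fold higher number from compound 1 to compound 3 (0.30 log units; within the scatter); that step stays within the usual scatter of this assay, so the two compounds cannot be told apart on these data. Within the data shown here, the one further value is the limit of compound 2, which stands at the limit of > 100000 nM in this assay, at which 1 of the 3 values shown sits.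

Compound 4 `C[C@H]1[C@H](NCc2cc(-c3ccccc3)cs2)C[C@H]2C[C@@H]1C2(C)C` differs from compound 3 in a single place: phenyl in place of cyclopropyl on an aromatic carbon. Among the measured compounds shown here, the only measured step at this position, from propyl to cyclopropyl, did not move the number beyond the scatter, and no measured step involves a phenyl group here, so there is no direct guide for this change. The change is larger than the one already measured, and a shift toward a lower number in this assay is expected to be possible but small. The estimate for compound 4 is therefore 12500 nM, within a range of 4000 nM to 35000 nM, a step of a 2.0-fold lower number from compound 3 to compound 4 (0.30 log units; within the scatter) that is expected to remain close to the scatter.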

Compound 4, minimum cytotoxic concentration: 5000 nM
Beside the measured number, compound 4's estimate is 2.5-fold (0.40 log units) above it, and the stated range covers the measured number.
By their numbers in this assay, from the lowest: compound 4; then compounds 1 and 3 (each within the scatter of the next). At a limit, above all of these: compound 2.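

In this assay, the group on this aromatic carbon, two ring bonds from the ring sulfur, does change the number: there is a 5.0-fold lower number from compound 3 to compound 4 (0.70 log units; beyond the scatter), and also a 2.5-fold lower number from compound 1 to compound 4 (0.40 log units; beyond the scatter). Both steps are modest but lie beyond the scatter, whereas the earlier exchange of propyl for cyclopropyl, a 2.0-fold higher number from compound 1 to compound 3 (0.30 log units; within the scatter), stayed within it. Among these three compounds, which differ only at this position, the phenyl group of compound 4 therefore goes with higher toxicity in this test, while compounds 1 and 3 cannot be told apart.

The compounds shown cannot separate the larger size of phenyl from its aromatic ring, and a cyclohexyl group, a pyridine ring or a phenyl ring carrying a fluorine or a methoxy group at this position would be needed to take that question further. The information at hand offers no measured reason for the shift seen with phenyl.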